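Iodo for Ethynyl on a Nucleoside Core: Cell Growth

The source may report more compounds than this note shows. Statements on the series, on what has been measured and on what is new or still open speak of the compounds shown alone.

Measured so far in an ADME assay on BJ cells (Homo sapiens), read by MTT assay, with a stated time of 72 h; on this read-out lower numbers stand for stronger inhibition and higher numbers for weaker inhibition:
compound 1 `C#Cc1cn([C@@H]2O[C@H](CO)[C@@H](O)[C@H]2O)c2ncnc(NC)c12` gives 86000 nM
compound 2 `C#Cc1cn([C@@H]2O[C@H](CO)[C@@H](O)[C@H]2O)c2nc(C)nc(N)c12` shows only a limit of the assay, > 100000 nM
compound 3 `Cc1nc(N)c2c(I)cn([C@@H]3O[C@H](CO)[C@@H](O)[C@H]3O)c2n1` gives 24600 nM

Compound 1 and compound 2 share all their atoms joined differently; the difference between the two cores is not broken down here. The value of compound 2 is a limit, not a number (the limit of > 100000 nM in this assay, at which 1 of the 3 values shown sits). One change appears twice among these compounds. From compound 2 to compound 3 it is iodo in place of ethynyl on an aromatic carbon and it gave an at least 4.0-fold lower number from compound 2 to compound 3 (0.60 log units; beyond the scatter). The unmeasured compound 4 `CNc1ncnc2c1c(I)cn2[C@@H]1O[C@H](CO)[C@@H](O)[C@H]1O` differs from compound 1 by the same change, (iodo in place of ethynyl on an aromatic carbon). A step of similar size is expected from compound 1, which gave 86000 nM, so a 3.4-fold lower number from compound 1 to compound 4 (0.54 log units; beyond the scatter) is estimated. Compound 4 is therefore expected near 25000 nM, plausibly between 8000 nM and 80000 nM.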

Compound 4, half-maximal inhibitory concentration: > 100000 nM
Compound 4 was reported as a limit (the forecaster's own chance of this, stated with the estimate: 10%); at least 4.0-fold (0.60 log units) between middle value and limit.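

Changing ethynyl to iodo did not carry over in the same way from one core to the other in this assay: the same change on two cores in this assay, an at least 4.0-fold lower number (0.60 log units; beyond the scatter) from compound 2 to compound 3 and an at least 1.1-fold higher number (0.06 log units; that floor lies within the scatter) from compound 1 to compound 4, at least 4.7-fold (0.67 log units) apart, beyond the scatter of two such steps

On the core of compound 1, the change gave an at least 1.1-fold higher number from compound 1 to compound 4 (0.06 log units; that floor lies within the scatter), but this is only a floor, as compound 4 is reported as a limit of the assay. A step seen on one core therefore cannot simply be assumed on the other, yet these two pairs, each resting on a limit, do not show the true size of the gap between the cores or why it arises.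

The compounds shown leave open how a bromo, a chloro or an amine on that same aromatic carbon would behave on each core.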